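Dodecyl and tetradecyl threonine sulfonamides on SiHa cells

The source may hold more compounds than are shown below. What is called first, only, known or untested is meant among the compounds shown, and "the series" means these compounds.

Measured so far:
compound 1 `CCCCCCCCCCCCNC(=O)[C@@H](NS(=O)(=O)c1ccc(C)cc1)[C@@H](C)O` gives 31600 nM
compound 2 `CCCCCCCCCCCCNC(=O)[C@@H](NS(=O)(=O)c1cccs1)[C@@H](C)O` gives 30900 nM
compound 3 `CCCCCCCCCCCCCCNC(=O)[C@@H](NS(=O)(=O)c1ccc(C)cc1)[C@@H](C)O` gives 19200 nM

These three values come from a functional assay on SiHa cells (Homo sapiens) for cytotoxicity, read by MTT assay, with a stated time of 48 h; a lower number here means a stronger inhibitor, a higher number a weaker inhibitor. The change from compound 1 to compound 2 is thiophen-2-yl in place of 4-methylphenyl on a sulfonyl sulfur, and it made a 1.0-fold lower number from compound 1 to compound 2 (0.01 log units; within the scatter). The change from compound 1 to compound 3 is ethyl in place of hydrogen on a saturated chain carbon, ten or more bonds along the chain from an amide-type nitrogen, and it made a 1.6-fold lower number from compound 1 to compound 3 (0.22 log units; within the scatter). Compound 4 `CCCCCCCCCCCCCCNC(=O)[C@@H](NS(=O)(=O)c1cccs1)[C@@H](C)O` is not yet measured; it differs from compound 3 by thiophen-2-yl in place of 4-methylphenyl on a sulfonyl sulfur, the same change as from compound 1 to compound 2, at the same place. Since compound 1 and compound 2 show a 1.0-fold lower number from compound 1 to compound 2 (0.01 log units; within the scatter), a step of about the same size is expected from compound 3 to compound 4 in this assay, that is a 1.0-fold lower number from compound 3 to compound 4 (0.00 log units; within the scatter). Compound 4 is therefore expected to give 19000 nM, with a range from 9000 nM to 40000 nM.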

Compound 4, half-maximal inhibitory concentration: 20400 nM
Compound 4: the middle estimate sits 1.1-fold (0.03 log units) below what was measured, and the stated range covers the measured number.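

In this assay thiophen-2-yl in place of 4-methylphenyl on a sulfonyl sulfur gives a 1.1-fold higher number from compound 3 to compound 4 (0.03 log units; within the scatter) on the tetradecyl core, and this step matches the one on the dodecyl core: the same change on two cores in this assay, a 1.0-fold lower number (0.01 log units; within the scatter) from compound 1 to compound 2 and a 1.1-fold higher number (0.03 log units; within the scatter) from compound 3 to compound 4, 1.1-fold (0.04 log units) apart, within the scatter of two such steps.
The tetradecyl for dodecyl change gives a 1.5-fold lower number from compound 2 to compound 4 (0.18 log units; within the scatter) with thiophen-2-yl on the sulfonyl sulfur, and this step also matches its counterpart: the same change on two cores in this assay, a 1.6-fold lower number (0.22 log units; within the scatter) from compound 1 to compound 3 and a 1.5-fold lower number (0.18 log units; within the scatter) from compound 2 to compound 4, 1.1-fold (0.04 log units) apart, within the scatter of two such steps.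
Within the data shown here, both changes therefore carry across these two cores without a detectable difference, but every step lies within the scatter, so this shows no effect of either change and no rule for steps of larger size.

Open, on these data alone, is whether a longer chain such as hexadecyl would give a step beyond the scatter. Also open, as far as these compounds go, is whether an amine or a carboxylic acid in place of 4-methylphenyl on a sulfonyl sulfur would do so.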